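Ring swap on the enone: nitro removed, chlorine added

A few compounds are considered here, and "the series" means these few. Any claim that something is new, unique, unknown or untested is made for them only; others in the source may bear on it.

Going by the values given here, compound 2 `O=C(/C(=C\c1ccc(F)c([N+](=O)[O-])c1)S(=O)(=O)c1ccc(Br)cc1)c1ccc(Br)cc1` stands at the top of the two numbers so far in a functional assay on DU-145 cells (Homo sapiens) for inhibition, read by trypan blue exclusion, with a stated time of 96 h; a lower number here means a stronger inhibitor of growth, a higher number a weaker inhibitor of growth: compound 2 gives 25000 nM. Among the compounds with values here, its nearest neighbour is compound 1 `O=C(/C(=C\c1csc([N+](=O)[O-])c1)S(=O)(=O)c1ccc(Br)cc1)c1ccc(Br)cc1`: in this assay compound 1 gives 1000 nM, and the only step so far, a 25-fold higher number from compound 1 to compound 2 (1.40 log units; beyond the scatter), shows that the aryl group on the double-bonded chain carbon governs the read-out strongly.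

Compound 3 `O=C(/C(=C\c1ccc(F)cc1Cl)S(=O)(=O)c1ccc(Br)cc1)c1ccc(Br)cc1` alters that same aryl group: 2-chloro-4-fluorophenyl in place of 4-fluoro-3-nitrophenyl on a double-bonded chain carbon bound to a double-bonded chain carbon. The measured step bears on this only in a general way, because a 25-fold higher number from compound 1 to compound 2 (1.40 log units; beyond the scatter) tells that changing the substituents on this ring can move the number a long way, but it gives no direction for removing the nitro group while adding chlorine. Within the data shown here, with only one step to lean on, the expectation is a modest gain, and the step is estimated as a 2.1-fold lower number from compound 2 to compound 3 (0.32 log units; beyond the scatter) in this assay. Compound 3 is therefore expected to give about 12000 nM in this assay, within a range from 3000 nM to 50000 nM.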

Compound 3, concentration for 50% growth inhibition: 50000 nM
The estimate for compound 3 lay 4.2-fold (0.62 log units) below the measured number; the range from low to high includes it.
By their numbers in this assay, from the lowest: compound 1; then compounds 2 and 3 (each within the scatter of the next).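

In this assay, 2-chloro-4-fluorophenyl in place of 4-fluoro-3-nitrophenyl on a double-bonded chain carbon bound to a double-bonded chain carbon gives a 2.0-fold higher number from compound 2 to compound 3 (0.30 log units; within the scatter), so this exchange, which removes the nitro group and brings in chlorine, does not separate the two compounds. The same position gives a 50-fold higher number from compound 1 to compound 3 (1.70 log units; beyond the scatter), which, together with the earlier step from compound 1 to compound 2, leaves compound 1 and its 5-nitrothiophen-3-yl group apart from both compounds with a six-membered aromatic ring of carbon only, and shows that a nitro group alone does not go with the low number, since compound 2 carries one and still stands with compound 3. No supporting data bear on the reason for these numbers.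

The compounds shown leave open whether the low number of compound 1 follows the thiophene ring or its nitro group, a question that a thiophene bearing an amine or a nitrile in place of the nitro group would address. From the compounds shown here alone, all three compounds share the same two bromophenyl groups, so what those groups contribute also remains open.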